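Hydroxyl groups in place of methoxy on the hydrazone aryl

This account rests on a few compounds, and the source may have more. Where it says the series, first, only, none or still open, it means among the compounds named here.

The series shares a core in which a hydrazone-linked aryl ring varies. Compound 1 `O=C(N/N=C/c1ccc(F)cc1)Nc1ccc(Oc2ccnc3[nH]ccc23)c(F)c1` gives 800 nM in a functional assay on MCF7 cells (Homo sapiens) for antiproliferative activity, read by MTT assay, with a stated time of 72 h; a higher number here means a weaker inhibitor, a lower number a stronger inhibitor. Within the data shown here, compound 2 `COc1ccc(/C=N/NC(=O)Nc2ccc(Oc3ccnc4[nH]ccc34)c(F)c2)cc1` gives 5750 nM in this assay, the highest of the two numbers measured so far; its nearest neighbour is compound 1, reached by a 7.2-fold higher number from compound 1 to compound 2 (0.86 log units; beyond the scatter). Compound 3 `O=C(N/N=C/c1ccc(O)cc1O)Nc1ccc(Oc2ccnc3[nH]ccc23)c(F)c1` has not yet been measured. The change from compound 2 to compound 3 is 2,4-dihydroxyphenyl in place of 4-methoxyphenyl on a carbon with a double bond to nitrogen. Among the measured compounds shown here, only one measured step exists, and it concerns a different change on the same ring, so it bears on this step only indirectly: it shows that a substituent change on this ring can shift the number well beyond the scatter. Given that the dihydroxyphenyl ring shares nothing with the methoxyphenyl it replaces, compound 3 is expected to differ from compound 2 by a 2.9-fold lower number from compound 2 to compound 3 (0.46 log units; beyond the scatter), and its value in this assay is estimated at 2000 nM with a range of 500 nM to 8000 nM.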

Compound 3, half-maximal inhibitory concentration: 48000 nM
Compound 3: the middle estimate sits 24-fold (1.38 log units) below what was measured; the whole stated range lies below it.
By their numbers in this assay, from the lowest: compound 1; then compound 2; then compound 3.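

In this assay, the 2,4-dihydroxyphenyl ring gives the highest number of the three compounds, with an 8.3-fold higher number from compound 2 to compound 3 (0.92 log units; beyond the scatter) and a 60-fold higher number from compound 1 to compound 3 (1.78 log units; beyond the scatter) on the same carbon with a double bond to nitrogen. So the earlier rise on going from 4-fluorophenyl to 4-methoxyphenyl was not the upper end for this position, and a ring carrying hydrogen-bond donors, which 4-methoxyphenyl lacks, stands weakest here. Nothing available accounts for this loss.

The change replaces the whole ring pattern at once, so the compounds shown do not separate the contribution of each hydroxyl group or tell whether a single hydroxyl would behave in the same way. As far as these compounds go, whether an amine or a carboxylic acid on this ring would follow the dihydroxyphenyl or the fluorophenyl also remains open.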